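This account rests on a few compounds, and the source may have more. Where it says the series, first, only, none or still open, it means among the compounds named here.

- Compound 1 `OCCCOc1c(Br)cc(Br)cc1Oc1ccc(Br)cc1Br`: 32.3 ug/mL
- Compound 2 `CC(=O)Oc1c(Br)cc(Br)cc1Oc1ccc(Br)cc1Br`: 32.3 ug/mL
- Compound 3 `C=CCOc1c(Br)cc(Br)cc1Oc1ccc(Br)cc1Br`: 29 ug/mL
- Compound 4 `Brc1ccc(Oc2cc(Br)cc(Br)c2OCc2ccccc2)c(Br)c1`: not yet measured

In a functional assay on U-937 cells (Homo sapiens) for cytotoxicity, read by MTT assay, with a stated time of 24 h (a higher number here means a weaker inhibitor, a lower number a stronger inhibitor), compound 1 gives 32.3 ug/mL. This is level with compound 2 and within the scatter of compound 3, so the three compounds cannot be separated on these numbers.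

Compound 4 keeps the core of compound 1 and changes one group: phenyl in place of 2-hydroxyethyl on a saturated chain carbon bound to an oxygen on an aromatic ring. Put simply, phenyl takes the place of 2-hydroxyethyl on a saturated chain carbon bound to an oxygen on an aromatic ring, which turns 3-hydroxypropyl into benzyl.

Going by the values given here, two measured steps bear on this change. The closer one, at the same place, is a 1.1-fold lower number from compound 1 to compound 3 (0.05 log units; within the scatter). The other is no change at the digits printed from compound 1 to compound 2 (within the scatter). Both lie within the scatter, as does a 1.1-fold lower number from compound 2 to compound 3 (0.05 log units; within the scatter). From the compounds shown here alone, none of the groups measured so far contains a ring, so the new phenyl is untested and the uncertainty stays wide. The estimated step is a 1.2-fold lower number from compound 1 to compound 4 (0.06 log units; within the scatter), and no change beyond the scatter is expected. For compound 4 the expected value is 28 ug/mL, with an estimated range of 15 ug/mL to 50 ug/mL.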

Compound 4, half-maximal inhibitory concentration: 29 ug/mL
The estimate for compound 4 lay 1.0-fold (0.02 log units) below the measured number; the range from low to high includes it.
By their numbers in this assay, from the lowest: compounds 3, 4, 1 and 2 (each within the scatter of the next).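

In this assay, going by these compounds alone, this is the first group on the oxygen to carry a ring, and compound 4 cannot be told apart from the compounds without one (a 1.1-fold lower number from compound 1 to compound 4 (0.05 log units; within the scatter); no change at the digits printed from compound 3 to compound 4 (within the scatter); a 1.1-fold lower number from compound 2 to compound 4 (0.05 log units; within the scatter)). Placing phenyl on the saturated chain carbon therefore brings in a six-membered aromatic ring and removes the hydrogen-bond donor and acceptor of 2-hydroxyethyl, without a step beyond the scatter. No measurement is available that explains why these four compounds read alike.

From the compounds shown here alone, it remains open whether a group carrying an amine or a carboxylic acid on this oxygen, or a much longer chain, would move the number beyond the scatter. The compounds shown also leave open whether a substituted benzyl would read like compound 4.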